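This account rests on a few compounds, and the source may have more. Where it says the series, first, only, none or still open, it means among the compounds named here.

In a functional assay on HUVEC cells (Homo sapiens), read by BrdU incorporation, with a stated time of 72 h (on this read-out lower numbers stand for stronger inhibition and higher numbers for weaker inhibition), compound 3 (`Cc1ccc2nc(Cl)c(/C=C/C(=O)c3ccc(I)s3)cc2c1`) gives 129 nM and sits level with compound 1 (`Cc1ccc2nc(Cl)c(/C=C/C(=O)c3sccc3C)cc2c1`) at 127 nM on this read-out. Compound 2 (`Cc1ccc2nc(Cl)c(/C=C/C(=O)c3cc(Cl)sc3Cl)cc2c1`) gives 26.2 nM and stands apart from both, with modest steps (a 4.8-fold lower number from compound 1 to compound 2 (0.69 log units; beyond the scatter)) and (a 4.9-fold higher number from compound 2 to compound 3 (0.69 log units; beyond the scatter)) that involve a dichlorothiophene and so bear little here. Compound 4 (`Cc1ccc2nc(Cl)c(/C=C/C(=O)c3ccc(C)s3)cc2c1`) differs from compound 3 by one exchange (methyl in place of iodo on an aromatic carbon), methyl in place of iodo on an aromatic carbon, next to the ring sulfur. The nearest evidence (a 1.0-fold higher number from compound 1 to compound 3 (0.01 log units; within the scatter)) exchanges a methylthiophene for 5-iodothiophen-2-yl and stays within the scatter. No step beyond the scatter is therefore expected in this assay for this exchange. The expected result (a 1.1-fold lower number from compound 3 to compound 4 (0.03 log units; within the scatter)) is small. Compound 4 is estimated at 120 nM with an expected range (50 nM to 290 nM) around it.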

Compound 4, half-maximal inhibitory concentration: 128 nM
Beside the measured number, compound 4's estimate is 1.1-fold (0.03 log units) below it; low and high end bracket the measured number.
By their numbers in this assay, from the lowest: compound 2; then compounds 1, 4 and 3 (each within the scatter of the next).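

Among these compounds, on the aromatic carbon next to the ring sulfur, iodo and methyl are not distinguished in this assay (a 1.0-fold lower number from compound 3 to compound 4 (0.00 log units; within the scatter)), the first direct exchange at this position. The 5-methylthiophen-2-yl and 3-methylthiophen-2-yl groups are likewise not distinguished (a 1.0-fold higher number from compound 1 to compound 4 (0.00 log units; within the scatter)), whereas 2,5-dichlorothiophen-3-yl remains apart (a 4.9-fold higher number from compound 2 to compound 4 (0.69 log units; beyond the scatter)). No measurement here offers an explanation for these results. As far as these compounds go, whether an amine or a carboxylic acid at this position would keep the same level remains open. Also open, from the compounds shown here alone, is whether the lower number of compound 2 follows its two chloro groups or its thiophene attachment.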